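The source may report more compounds than this note shows. Statements on the series, on what has been measured and on what is new or still open speak of the compounds shown alone.

Of the compounds shown here, three built on one shared core have so far been measured. Compound 1 `[O-][S+](CCNC1CCN(CC(O)Cc2ccccc2)CC1)C(c1ccc(F)cc1)c1ccc(F)cc1` gives 351 nM in an assay on membranes from Cortex for displacement of a labelled ligand from Sigma non-opioid intracellular receptor 1 (Cavia porcellus), read by scintillation counting, with a stated time of 120 min; on this read-out higher numbers stand for weaker inhibition and lower numbers for stronger inhibition. Compound 2 `O=C(c1ccc(F)cc1)N1CCC(NCC[S+]([O-])C(c2ccc(F)cc2)c2ccc(F)cc2)CC1` gives 1440 nM in this assay, and compound 3 `CC(C)(C)CN1CCC(NCC[S+]([O-])C(c2ccc(F)cc2)c2ccc(F)cc2)CC1` gives 542 nM in this assay. Compound 3 thus holds the second highest of the three numbers: its nearest neighbour is compound 1, since a 1.5-fold higher number from compound 1 to compound 3 (0.19 log units; within the scatter), and its farthest is compound 2. Compound 4 `O=C(c1ccc(F)cc1F)N1CCC(NCC[S+]([O-])C(c2ccc(F)cc2)c2ccc(F)cc2)CC1` differs from compound 3 by (2,4-difluorophenyl)carbonyl in place of neopentyl on an amine nitrogen in a ring. Within the data shown here, two measured steps bear on this change. First, a 4.1-fold higher number from compound 1 to compound 2 (0.61 log units; beyond the scatter); second, a 2.7-fold lower number from compound 2 to compound 3 (0.42 log units; beyond the scatter). Because a 2.7-fold lower number from compound 2 to compound 3 (0.42 log units; beyond the scatter) accompanied the exchange of a (4-fluorophenyl)carbonyl for neopentyl on that ring nitrogen, the reverse exchange here, with a (2,4-difluorophenyl)carbonyl entering instead, is expected to move the number back up, by about a 2.4-fold higher number from compound 3 to compound 4 (0.38 log units; beyond the scatter) in this assay. Compound 4 is therefore estimated at 1300 nM in this assay, with a range from 500 nM to 3500 nM.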

Compound 4, inhibition constant: 171 nM
Estimate against measurement, compound 4: 7.6-fold (0.88 log units) above; the whole stated range lies above it.
By their numbers in this assay, from the lowest: compound 4; then compounds 1 and 3 (each within the scatter of the next); then compound 2.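

On the ring nitrogen, a carbonyl-linked aryl group does not by itself go with a higher number in this assay: with (2,4-difluorophenyl)carbonyl in place of neopentyl, the measurement shows a 3.2-fold lower number from compound 3 to compound 4 (0.50 log units; beyond the scatter). The sharpest contrast comes from fluoro in place of hydrogen on an aromatic carbon, a change of one atom that gives an 8.4-fold lower number from compound 2 to compound 4 (0.93 log units; beyond the scatter) and is the largest step in the set. The measurement also shows a 2.1-fold lower number from compound 1 to compound 4 (0.31 log units; beyond the scatter), so compound 4 now holds the lowest number of the four, with every step to it printed as beyond the scatter.

Nothing available explains why the added fluoro has so large an effect. As far as these compounds go, whether chloro or methoxy in that fluoro's place would give a similar number stays open, as does the outcome of a sulfonyl in place of the carbonyl.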